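A few compounds are considered here, and "the series" means these few. Any claim that something is new, unique, unknown or untested is made for them only; others in the source may bear on it.

Of the compounds shown here, three sharing one core have been measured for how large a response they reach. In an assay on isolated protein for agonist activity at Bile acid receptor (Homo sapiens), read by FRET (a lower number here means a smaller maximal response, a higher number a larger maximal response), compound 1 `CC(C)c1onc(-c2c(Cl)cccc2Cl)c1COc1ccc(N(C)C(=O)c2ccc(C(=O)O)cc2)c(C(F)(F)F)n1` gives 101%, compound 2 `CC(C)c1onc(-c2c(Cl)cccc2Cl)c1COc1ccc(N(C)C(=O)c2cccc(C(=O)O)c2)c(C(F)(F)F)n1` gives 110%, and compound 3 `CC(C)c1onc(-c2c(Cl)cccc2Cl)c1COc1ccc(N(C)Cc2ccc(C(=O)NS(C)(=O)=O)cc2)c(C(F)(F)F)n1` gives 105%. Compound 3 is second highest of the three numbers, yet its gaps to compound 1 and to compound 2 both lie within the scatter. Compound 4 `CC(C)c1onc(-c2c(Cl)cccc2Cl)c1COc1ccc(N(C)Cc2ccc(OCCO)cc2)c(C(F)(F)F)n1` differs from compound 3 in one place: 2-hydroxyethoxy in place of (methylsulfonyl)carbamoyl on an aromatic carbon. Within the data shown here, the only measured step, a number 9 percentage points higher from compound 1 to compound 2 (within the scatter), alters a different part of the molecule and stayed within the scatter, so no measured step bears directly on this change. Since all three numbers sit near a full response, compound 4 is expected to give about 100%, between 85% and 115%. That would be an expected step of a number 5 percentage points lower from compound 3 to compound 4 (within the scatter).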

Compound 4, largest response reached (reported as efficacy), in percent of the reference or control that the assay uses: 87%
Beside the measured number, compound 4's estimate is 13 percentage points above it, within the range that was stated.
By their numbers in this assay, from the lowest: compound 4; then compounds 1, 3 and 2 (each within the scatter of the next).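

In this assay, among these compounds, the group on this aromatic carbon turns out to matter: a number 18 percentage points lower from compound 3 to compound 4 (beyond the scatter) comes with 2-hydroxyethoxy replacing (methylsulfonyl)carbamoyl, whereas the one earlier step stayed within the scatter. The larger swaps to 4-(2-hydroxyethoxy)benzyl on the nitrogen point the same way, with a number 23 percentage points lower from compound 2 to compound 4 (beyond the scatter) and a number 14 percentage points lower from compound 1 to compound 4 (beyond the scatter) as the printed steps. No available evidence explains this drop. Still open, as far as these compounds go, is whether an amine, or a longer chain ending in a hydroxyl, on this aromatic carbon would restore the larger response.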